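This account rests on a few compounds, and the source may have more. Where it says the series, first, only, none or still open, it means among the compounds named here.

Compound 1 `CC(C)(O)C#Cc1cc(C(O)(C(F)(F)F)C(F)(F)F)cnc1N1CCN(S(=O)(=O)c2ccc(N)nc2)CC1`: 16 mL.min-1.g-1
Compound 2 `CS(=O)(=O)Nc1cccc(-c2cc(C(O)(C(F)(F)F)C(F)(F)F)cnc2N2CCN(S(=O)(=O)c3ccc(N)nc3)CC2)c1`: 81 mL.min-1.g-1
Compound 3 `CS(=O)(=O)c1ccc(-c2cc(C(O)(C(F)(F)F)C(F)(F)F)cnc2N2CCN(S(=O)(=O)c3ccc(N)nc3)CC2)cc1`: 103 mL.min-1.g-1

In an ADME assay (liver) for metabolic stability, with Liver microsome (Rattus norvegicus) as the target, using microsomes and NADPH, with a stated time of 30 min, tested at 1 uM (a lower number here means slower removal, a higher number faster removal of the compound), compound 1 has the lowest of the three numbers. The steps of a 5.1-fold higher number from compound 1 to compound 2 (0.70 log units; beyond the scatter) and a 6.4-fold higher number from compound 1 to compound 3 (0.81 log units; beyond the scatter) are both beyond the scatter and modest in size, whereas a 1.3-fold higher number from compound 2 to compound 3 (0.10 log units; within the scatter) lies within it. Compound 4 `Cc1ccc(-c2cc(C(O)(C(F)(F)F)C(F)(F)F)cnc2N2CCN(S(=O)(=O)c3ccc(N)nc3)CC2)cn1` differs from compound 1 by 6-methylpyridin-3-yl in place of 3-hydroxy-3-methylbut-1-yn-1-yl on an aromatic carbon. The two measured steps away from compound 1 both exchange the 3-hydroxy-3-methylbut-1-yn-1-yl group for a 3-(methanesulfonamido)phenyl or a 4-(methylsulfonyl)phenyl group at the same place, and both raised the number by a similar modest amount, so a comparable upward step is expected here, estimated as a 5.3-fold higher number from compound 1 to compound 4 (0.73 log units; beyond the scatter). Compound 4 is therefore expected at about 85 mL.min-1.g-1, within a range from 35 mL.min-1.g-1 to 200 mL.min-1.g-1.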

Compound 4, intrinsic clearance in microsomes: 182 mL.min-1.g-1
Estimate against measurement, compound 4: 2.1-fold (0.33 log units) below; the range from low to high includes it.
By their numbers in this assay, from the lowest: compound 1; then compounds 2, 3 and 4 (each within the scatter of the next, the first and the last beyond it).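

In this assay the 6-methylpyridin-3-yl group, which carries no sulfonyl group, gives the largest step yet at this position (an 11-fold higher number from compound 1 to compound 4 (1.06 log units; beyond the scatter)), so the rise seen on leaving the 3-hydroxy-3-methylbut-1-yn-1-yl group does not require a sulfonyl-bearing ring. The aromatic replacements are not all alike: one step (a 1.8-fold higher number from compound 3 to compound 4 (0.25 log units; within the scatter)) stays within the scatter, while another (a 2.2-fold higher number from compound 2 to compound 4 (0.35 log units; beyond the scatter)) goes beyond it. Nothing given here accounts for these changes. As far as these compounds go, whether a 3-methoxyprop-1-yn-1-yl chain or a saturated piperidinyl ring at this place would stay near compound 1 or rise towards compound 4 remains open.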